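Hydrazone thioether series: heteroaryl exchange on compound 2

This account rests on a few compounds, and the source may have more. Where it says the series, first, only, none or still open, it means among the compounds named here.

Measured compounds:
compound 1 `O=C(CSc1nnnn1-c1ccccc1)N/N=c1/scc(-c2ccc(Br)cc2)n1-c1ccccc1` — 20.4%
compound 2 `Cc1ccc(-c2cs/c(=N/NC(=O)CSc3nnnn3-c3ccccc3)n2-c2ccccc2)cc1` — 22.2%
compound 3 `O=C(CSc1nnnn1-c1ccccc1)N/N=c1/scc(-c2ccc(F)cc2)n1-c1ccccc1` — 30.6%

In a functional assay on C6 cells (Rattus norvegicus) for cytotoxicity, read by MTT assay, with a stated time of 24 h, tested at 200 ug/mL (a lower number here means a stronger effect, a higher number a weaker effect of the compound at the concentration tested), compound 1 gives 20.4%, compound 2 gives 22.2% and compound 3 gives 30.6%. Compound 2 holds the second highest of the three numbers. Its steps to both neighbours stay inside the scatter: a number 1.8 percentage points higher from compound 1 to compound 2 (within the scatter) and a number 8.4 percentage points higher from compound 2 to compound 3 (within the scatter). Among the compounds with values here, only the step of a number 10.2 percentage points higher from compound 1 to compound 3 (beyond the scatter) lies beyond the scatter, and that one is modest.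

Compound 4 `Cc1ccc(-c2cs/c(=N/NC(=O)CSc3nnc(C)s3)n2-c2ccccc2)cc1` differs from compound 2 in a single place: 5-methyl-1,3,4-thiadiazol-2-yl in place of 1-phenyl-1H-tetrazol-5-yl on a sulfur. Every measured step in this set changes the substituent on the aromatic carbon and leaves the group on the sulfur untouched, so none of them bears on the change from compound 2 to compound 4. Within the data shown here, with no step to lean on, the expectation is simply that the number stays close to that of compound 2, with a wide range, and the expected step of a number 0.2 percentage points lower from compound 2 to compound 4 (within the scatter) is not expected to clear the scatter. Compound 4 is therefore estimated at 22%, within 8% to 40%.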

Compound 4, a percentage reported as activity, at one concentration (the size of the read-out at that concentration, not a potency): 13.3%
Beside the measured number, compound 4's estimate is 8.7 percentage points above it; low and high end bracket the measured number.
By their numbers in this assay, from the lowest: compounds 4, 1, 2 and 3 (each within the scatter of the next, the first and the last beyond it).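

In this assay, within the data shown here, the exchange of 1-phenyl-1H-tetrazol-5-yl for 5-methyl-1,3,4-thiadiazol-2-yl gives the first reading at the sulfur, a step of a number 8.9 percentage points lower from compound 2 to compound 4 (within the scatter). The entering group lacks the six-membered aromatic ring of carbon only and has a single five-membered aromatic ring, yet the step stays inside the scatter, so in this one pair that phenyl-bearing tetrazole is not needed to keep the read-out at the tested concentration. Nothing available accounts for the size of this step.

From the compounds shown here alone, whether the exchange reads the same with bromo or fluoro in place of the methyl on the aromatic carbon remains open. Also open, going by these compounds, is what a non-aromatic group on the sulfur, such as a short chain ending in an amine or a carboxylic acid, would give.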